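Isopropylamino Replaces Methoxy on the Carbonyl Carbon

A few compounds are considered here, and "the series" means these few. Any claim that something is new, unique, unknown or untested is made for them only; others in the source may bear on it.

Compound 1 `COC(=O)c1ccc(/C=C/C(=O)c2cc(OC)ccc2OC)cc1` gives 3510 nM in a functional assay on NTUB1 cells (Homo sapiens) for cytotoxicity, read by MTT assay, with a stated time of 72 h (a lower number here means a stronger inhibitor, a higher number a weaker inhibitor), the lowest of the three numbers measured. Compound 2 `CCOC(=O)c1ccc(/C=C/C(=O)c2cc(OC)ccc2OC)cc1` gives 4490 nM, and a 1.3-fold higher number from compound 1 to compound 2 (0.11 log units; within the scatter). Compound 3 `COc1ccc(OC)c(C(=O)/C=C/c2ccc(C(=O)OCc3ccccc3)cc2)c1` gives 13300 nM; here a 3.8-fold higher number from compound 1 to compound 3 (0.58 log units; beyond the scatter) and a 3.0-fold higher number from compound 2 to compound 3 (0.47 log units; beyond the scatter). Compound 4 `COc1ccc(OC)c(C(=O)/C=C/c2ccc(C(=O)NC(C)C)cc2)c1` differs from compound 1 by isopropylamino in place of methoxy on a carbonyl carbon. For the measured compounds named here, none of the measured steps exchanges the methoxy itself; they only vary the group on the saturated chain carbon bound to the oxygen, and larger groups gave modestly higher numbers. Going by the values given here, no step directly bears on this change, so the step from compound 1 to compound 4 is expected to be a 1.6-fold higher number from compound 1 to compound 4 (0.20 log units; within the scatter), with wide uncertainty. Compound 4 is therefore estimated at 5500 nM, between 1500 nM and 20000 nM.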

Compound 4, half-maximal inhibitory concentration: 1970 nM
The estimate for compound 4 lay 2.8-fold (0.45 log units) above the measured number, and the stated range covers the measured number.
By their numbers in this assay, from the lowest: compounds 4, 1 and 2 (each within the scatter of the next, the first and the last beyond it); then compound 3.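

In this assay, isopropylamino on the carbonyl carbon does not separate from methoxy (a 1.8-fold lower number from compound 1 to compound 4 (0.25 log units; within the scatter)), but it does separate from ethoxy (a 2.3-fold lower number from compound 2 to compound 4 (0.36 log units; beyond the scatter)) and from benzyloxy (a 6.8-fold lower number from compound 3 to compound 4 (0.83 log units; beyond the scatter)). A group joined through nitrogen and carrying a hydrogen-bond donor is therefore compatible with this position, and it avoids the higher number seen with benzyloxy. Nothing available explains these differences. Still open, going by these compounds, is how a carboxylic acid or a longer chain on the nitrogen would read at this carbonyl carbon. A dimethylamino group would show whether the amide hydrogen matters.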